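Amide aryl swap in a cytotoxicity series

A few compounds are considered here, and "the series" means these few. Any claim that something is new, unique, unknown or untested is made for them only; others in the source may bear on it.

Compound 2 `CC(C)n1ncc2c(C(=O)Nc3cccc(S(N)(=O)=O)c3)cc(-c3cccs3)nc21` gives 25000 nM in an ADME assay on LLC-MK2 cells (Macaca mulatta) for cytotoxicity, read by spectrophotometry and crystal violet staining, with a stated time of 4 days (a lower number here means that less compound is tolerated, a higher number that more compound is tolerated), and stands level with compound 1 `CNS(=O)(=O)c1cccc(NC(=O)c2cc(-c3cccs3)nc3c2cnn3C(C)C)c1`, which gives 25000 nM; the step of no change at the digits printed from compound 1 to compound 2 (within the scatter) lies within the scatter. Compound 3 `CC(C)n1ncc2c(C(=O)Nc3cccc(S(=O)(=O)N(C)C)c3)cc(-c3cccs3)nc21` reaches only the limit > 200000 nM in this assay. The steps of an at least 8.0-fold higher number from compound 2 to compound 3 (0.90 log units; beyond the scatter) and an at least 8.0-fold higher number from compound 1 to compound 3 (0.90 log units; beyond the scatter) are both at least modest and both end at the limit (the limit of > 200000 nM in this assay, at which 1 of the 3 values shown sits). Compound 4 `CC(C)n1ncc2c(C(=O)Nc3ccccn3)cc(-c3cccs3)nc21` carries pyridin-2-yl in place of 3-sulfamoylphenyl on an amide-type nitrogen. Within the data shown here, none of the measured steps touches this change: all three concern the sulfonamide nitrogen, while here the whole aryl group is exchanged, so they give no direct guide. The step of a 1.6-fold higher number from compound 2 to compound 4 (0.20 log units; within the scatter) in this assay is therefore expected to stay within the scatter, with wide uncertainty. Compound 4 is estimated at 40000 nM, ranging from 10000 nM to 200000 nM.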

Compound 4, half-maximal cytotoxic concentration: > 200000 nM
Compound 4 was reported as a limit; the forecaster's own chance of this, stated with the estimate: 30%; middle value at least 5.0-fold (0.69 log units) from the limit.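

Replacing 3-sulfamoylphenyl with pyridin-2-yl on the amide-type nitrogen gives an at least 8.0-fold higher number from compound 2 to compound 4 (0.90 log units; beyond the scatter) in this assay, so changes at this position reach beyond the sulfonamide nitrogen. Going by these compounds, the value of compound 4 is a limit, so the full size of this step stays unknown. Compound 4 shares that limit with compound 3: the limit of > 200000 nM in this assay, at which 2 of the 4 values shown sit.

Compound 3 and compound 4 cannot be ranked against each other. Also open, on these data alone, is how a plain phenyl or a 3-aminophenyl on the same nitrogen would read, which would separate loss of the sulfamoyl group from entry of the ring nitrogen.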